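The source may report more compounds than this note shows. Statements on the series, on what has been measured and on what is new or still open speak of the compounds shown alone.

Measured so far:
compound 1, `Cc1nn(C)c2c1C(c1ccccc1)=NCC(=O)N2`: 16 mg/kg
compound 2, `CCc1nn(C)c2c1C(c1ccccc1)=NCC(=O)N2`: 8 mg/kg
compound 3, `CCn1nc(C)c2c1NC(=O)CN=C2c1ccccc1Cl`: 8 mg/kg

In a functional assay on the whole organism with Rattus norvegicus as the target (on this read-out higher numbers stand for an effect only at larger amounts of compound and lower numbers for an effect already at smaller amounts), compound 1 gives 16 mg/kg, compound 2 gives 8 mg/kg and compound 3 gives 8 mg/kg. Compound 1 and compound 2 differ by methyl in place of hydrogen on a saturated chain carbon bound to an aromatic carbon, and on this assay that change made a 2.0-fold lower number from compound 1 to compound 2 (0.30 log units; within the scatter). Compound 3 and compound 2 give the same number at the digits shown; the difference between the core of compound 3 and the core of compound 1 is not broken down here.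

Compound 4, `CCCn1nc(C)c2c1NC(=O)CN=C2c1ccccc1Cl`, is still to be measured on this assay. It differs from compound 3 by methyl in place of hydrogen on a saturated chain carbon, two bonds along the chain from an aromatic nitrogen. This is the same kind of change as that from compound 1 to compound 2, but the surroundings differ: in the earlier pair the carbon is bound to an aromatic carbon, here it lies two bonds along the chain from an aromatic nitrogen.

The step is expected to be a 1.3-fold lower number from compound 3 to compound 4 (0.12 log units; within the scatter), resting on the step of a 2.0-fold lower number from compound 1 to compound 2 (0.30 log units; within the scatter) seen with compound 1 and compound 2, and on the different place of the change. Compound 4 is expected at about 6 mg/kg, estimated between 3 mg/kg and 16 mg/kg.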

Compound 4, minimum effective dose: 63 mg/kg
Estimate against measurement, compound 4: 11-fold (1.02 log units) below, outside the stated range (above it).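

In this assay, extending ethyl to propyl gave a 7.9-fold higher number from compound 3 to compound 4 (0.90 log units; beyond the scatter), so this step lies beyond the scatter and runs the opposite way to the earlier one. Set beside that earlier step, the addition of one methyl did not carry over from the core of compound 1 to the core of compound 3: the same change on two cores in this assay, a 2.0-fold lower number (0.30 log units; within the scatter) from compound 1 to compound 2 and a 7.9-fold higher number (0.90 log units; beyond the scatter) from compound 3 to compound 4, 16-fold (1.20 log units) apart, beyond the scatter of two such steps. For the compounds shown here, this shows that the earlier result cannot simply be transferred, but it does not show whether the core or the place of the change accounts for the gap, since each core offers only one pair and the change falls on a carbon bound to an aromatic carbon in one pair and on a carbon two bonds along the chain from an aromatic nitrogen in the other.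

The compounds shown leave open whether a butyl chain or an isopropyl group in place of the propyl would follow compound 4. They also leave open whether methyl to ethyl on the carbon-bound chain would behave on the core of compound 3 as it did on the core of compound 1.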